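A few compounds are considered here, and "the series" means these few. Any claim that something is new, unique, unknown or untested is made for them only; others in the source may bear on it.

Going by the values given here, compound 3 `CCCCCCCCCCCCCCNC(=O)[C@@H](NC(=O)c1cccs1)[C@@H](C)O` gives the lowest of the three numbers so far in a functional assay on A-431 cells (Homo sapiens) for cytotoxicity, read by MTT assay, with a stated time of 48 h (on this read-out higher numbers stand for weaker inhibition and lower numbers for stronger inhibition), at 26500 nM. Its nearest neighbour is compound 1 `CCCCCCCCNC(=O)[C@@H](NC(=O)/C=C/c1ccccc1)[C@@H](C)O`, which gives 36000 nM, a gap that stays within the usual scatter, so the two cannot be told apart. Among the compounds with values here, compound 2 `CCCCCCCCCCCCCCNC(=O)[C@@H](NC(=O)c1ccco1)[C@@H](C)O` gives 190000 nM, and the only single-point step among the measured compounds, a 7.2-fold lower number from compound 2 to compound 3 (0.86 log units; beyond the scatter), is the one that sets it apart.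

Compound 4 `CCCCCCCCCCCCCCNC(=O)[C@@H](NC(=O)/C=C/c1ccccc1)[C@@H](C)O` keeps the core of compound 3 and changes one group: 2-phenylethenyl in place of thiophen-2-yl on a carbonyl carbon. Within the data shown here, no measured step repeats this exact exchange, so the step from compound 2 to compound 3 does not speak to it directly. What bears on it is that compound 1 carries the same 2-phenylethenyl group on a shorter chain and sits within the scatter of compound 3. For compound 4 the step of a 1.1-fold higher number from compound 3 to compound 4 (0.05 log units; within the scatter) is therefore expected to stay within the scatter, in no clear direction. Compound 4 is estimated at 30000 nM, with a range from 10000 nM to 90000 nM.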

Compound 4, half-maximal inhibitory concentration: 64900 nM
Beside the measured number, compound 4's estimate is 2.2-fold (0.34 log units) below it; low and high end bracket the measured number.
By their numbers in this assay, from the lowest: compounds 3, 1 and 4 (each within the scatter of the next, the first and the last beyond it); then compound 2.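

With the tetradecyl-bearing core of compound 3 held fixed, the group on the carbonyl carbon changes the number in this assay in both directions: 2-phenylethenyl in place of thiophen-2-yl gives a 2.4-fold higher number from compound 3 to compound 4 (0.39 log units; beyond the scatter) and 2-phenylethenyl in place of furan-2-yl gives a 2.9-fold lower number from compound 2 to compound 4 (0.47 log units; beyond the scatter) on the same chain. On this chain the three groups therefore fall into a clear order, with thiophen-2-yl giving the lowest number, 2-phenylethenyl the middle one and furan-2-yl the highest. With 2-phenylethenyl kept, hexyl in place of hydrogen on the saturated chain gives a 1.8-fold higher number from compound 1 to compound 4 (0.26 log units; within the scatter) and so shows no readable effect of the chain for this pair.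

On these data alone, whether this order holds on the shorter chain, and where a cyclohexyl or aminomethyl group on the carbonyl carbon would fall, stays open. No measurement shown here accounts for the order of these groups.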